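A Fluorine Shift on the Phenyl Ether

This account rests on a few compounds, and the source may have more. Where it says the series, first, only, none or still open, it means among the compounds named here.

Values in a functional assay on CRL2813 cells (Homo sapiens) for antiproliferative activity, read by sulforhodamine B assay, with a stated time of 3 days, in the presence of a further agent that is not named here (on this read-out higher numbers stand for weaker inhibition and lower numbers for stronger inhibition), for the two measured compounds:
- compound 1 `O=C(Nc1cccc(C(F)(F)F)c1)N[C@H]1CC[C@H](Oc2ccc(C(F)(F)F)cc2)CC1` gives 5000 nM
- compound 2 `O=C(Nc1cccc(C(F)(F)F)c1)N[C@H]1CC[C@H](Oc2cccc(F)c2)CC1` gives 29900 nM

Of this pair, compound 2 has the higher number and is therefore the weaker inhibitor in this assay. Among the measured compounds shown here, only one measured step is available, a 6.0-fold higher number from compound 1 to compound 2 (0.78 log units; beyond the scatter), and it is modest but beyond the scatter. That step replaced 4-(trifluoromethyl)phenyl with 3-fluorophenyl on an oxygen on a saturated carbon.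

The next compound, compound 3 `O=C(Nc1cccc(C(F)(F)F)c1)N[C@H]1CC[C@H](Oc2ccccc2F)CC1`, changes the same place, with 2-fluorophenyl in place of 3-fluorophenyl on an oxygen on a saturated carbon. The two compounds have the same atoms, joined differently. For the measured compounds named here, the measured step bears on this change only loosely, since it exchanged a different group, and no measured pair compares 3-fluorophenoxy with 2-fluorophenoxy. A shift as large as a 6.0-fold higher number from compound 1 to compound 2 (0.78 log units; beyond the scatter) therefore seems possible in either direction, but no change beyond the scatter is expected in this assay. The expected step is a 1.2-fold lower number from compound 2 to compound 3 (0.08 log units; within the scatter) and is only a rough estimate. For compound 3 the estimated value is 25000 nM, with an expected range from 10000 nM to 55000 nM.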

Compound 3, half-maximal inhibitory concentration: 21900 nM
Compound 3: the middle estimate sits 1.1-fold (0.06 log units) above what was measured, within the range that was stated.
By their numbers in this assay, from the lowest: compound 1; then compounds 3 and 2 (each within the scatter of the next).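

In this assay, 2-fluorophenyl in place of 3-fluorophenyl on the oxygen gives a 1.4-fold lower number from compound 2 to compound 3 (0.14 log units; within the scatter), so this read-out does not separate these two fluorophenoxy isomers. Compound 1 now stands apart from a second fluorophenoxy compound, with a 4.4-fold higher number from compound 1 to compound 3 (0.64 log units; beyond the scatter), which shows that the gap first seen with compound 2 is not confined to 3-fluorophenyl and holds for both fluorophenyl groups shown. Nothing available here accounts for either the gap or the lack of separation between the isomers.

The three compounds leave open whether a group other than fluorine or trifluoromethyl on this phenyl ring, such as a methoxy group, a nitrile or an amine, would match or pass compound 1, which itself stands at 5000 nM in this assay. Every change shown also falls on the same side of the shared core, so what a carboxylic acid or a longer chain would do elsewhere on it remains an open question.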